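This account rests on a few compounds, and the source may have more. Where it says the series, first, only, none or still open, it means among the compounds named here.

Compound 2 `Cc1ccccc1NC(=O)/C=C/c1coc2cc(O)ccc2c1=O` in an ADME assay on HepG2 2.2.15 cells (Homo sapiens) for cytotoxicity, read by MTT assay, with stated times of 48 h and 9 days (a higher number here means that more compound is tolerated, a lower number that less compound is tolerated), gives 374000 nM. Compound 1 `COc1ccc2c(=O)c(/C=C/C(=O)NCc3cccc(F)c3)coc2c1` gives 475000 nM, a number within the usual scatter of that, while compound 3 `O=C(/C=C/c1coc2cc(O)ccc2c1=O)Nc1ccccc1` gives 821000 nM, clearly higher. Within the data shown here, the only measured single-point step is a 2.2-fold higher number from compound 2 to compound 3 (0.34 log units; beyond the scatter), and it concerns a different site than the one changed here. Compound 4 `COc1ccc2c(=O)c(/C=C/C(=O)Nc3ccccc3C)coc2c1` differs from compound 2 by methyl in place of hydrogen on an oxygen on an aromatic ring. Among the measured compounds shown here, no measured step covers this exact change; the closest hint is compound 1, which carries a methoxy at this position and gives 475000 nM, within the scatter of compound 2. Compound 4 is therefore expected to show a 1.1-fold higher number from compound 2 to compound 4 (0.03 log units; within the scatter), no shift beyond the scatter. Compound 4 is estimated at 400000 nM, with a range from 200000 nM to 800000 nM.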

Compound 4, half-maximal cytotoxic concentration: 59700 nM
Estimate against measurement, compound 4: 6.7-fold (0.83 log units) above; measured number below the stated range.
By their numbers in this assay, from the lowest: compound 4; then compounds 2, 1 and 3 (each within the scatter of the next, the first and the last beyond it).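

Hydroxy to methoxy on the aromatic ring is not a neutral swap when 2-methylphenyl sits on the amide-type nitrogen: in this assay, less compound is tolerated (a 6.3-fold lower number from compound 2 to compound 4 (0.80 log units; beyond the scatter)). Compound 1 also carries the methoxy, yet the group on that nitrogen still counts (an 8.0-fold lower number from compound 1 to compound 4 (0.90 log units; beyond the scatter)), so the methoxy alone does not set the number. Nothing available explains this shift. Still open, as far as these compounds go, is how an ethoxy or a longer chain on this oxygen would read, and whether an amine on the phenyl ring would alter the picture.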